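Shrinking a cyclohexyl to a methyl on a weak antiproliferative

This account rests on a few compounds, and the source may have more. Where it says the series, first, only, none or still open, it means among the compounds named here.

Measured compounds:
compound 1, `O[C@H]1CO[C@H](COCc2ccccc2)[C@@H](OCc2ccccc2)[C@@H]1OCc1ccccc1`: "not active" (no number reported)
compound 2, `C=C[C@H]1O[C@H](COCc2ccccc2)[C@@H](OCc2ccccc2)[C@H](OCc2ccccc2)[C@H]1O`: "not active" (no number reported)
compound 3, `O[C@@H]1[C@@H](OCc2ccccc2)[C@H](OCc2ccccc2)[C@@H](COCc2ccccc2)O[C@@H]1CC1CCCCC1`: 17200 nM

Three compounds with a shared protected sugar core have been examined in a functional assay on HL-60 cells (Homo sapiens) for antiproliferative activity, read by MTT assay; on this read-out lower numbers stand for stronger inhibition and higher numbers for weaker inhibition. Compound 1 carries a hydroxyl at the position of interest and is reported in this assay as "not active" (no number reported). Compound 2, with a vinyl group there, is likewise reported as "not active" (no number reported). Going by the values given here, compound 3, bearing a cyclohexylmethyl substituent, is the only member with a numerical result in this assay, where compound 3 gives 17200 nM, a weak inhibition.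

Compound 4, `CC[C@H]1O[C@H](COCc2ccccc2)[C@@H](OCc2ccccc2)[C@H](OCc2ccccc2)[C@H]1O`, is the next compound to be measured in this assay. It differs from compound 3 by the change (methyl in place of cyclohexyl on a saturated chain carbon bound to a saturated ring carbon). Among the compounds with values here, since no step between two measured compounds is available, the direction of this change can only be anticipated from the three results above: the two compounds with smaller groups at this position show no measurable activity, and compound 3 itself is already weak.

For compound 4 a weakening beyond the scatter, a 2.0-fold higher number from compound 3 to compound 4 (0.31 log units; beyond the scatter), is expected, with a considerable chance that no number is obtained at all. The estimated value for compound 4 in this assay is 35000 nM, within a range from 12000 nM to 90000 nM.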

Compound 4, half-maximal inhibitory concentration: "not active" (no number reported)
The entry for compound 4 holds no number, so the estimate cannot be set against anything.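

Going by these compounds alone, compound 4 carries no number in this assay, so no step from compound 3 to compound 4 can be read. The compounds shown leave open how far activity in this assay depends on the group at this place, with compound 3 alone giving a number, 17200 nM. No measurement here bears on the reason for this result.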